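This account rests on a few compounds, and the source may have more. Where it says the series, first, only, none or still open, it means among the compounds named here.

In a functional assay on NCI-H1975 cells (Homo sapiens) for cytotoxicity, read by MTT assay, with a stated time of 72 h (a lower number here means a stronger inhibitor, a higher number a weaker inhibitor), compound 1 `O=C(N/N=C/c1ccc(Br)cc1)N1CCc2ncnc(Nc3ccc(F)c(Cl)c3)c2C1` gives > 200000 nM, which is a limit of the assay. Compound 2 `O=C(N/N=C/c1ccccc1)N1CCc2ncnc(Nc3ccc(F)c(Cl)c3)c2C1` gives 28800 nM and compound 3 `O=C(N/N=C/c1ccc(Br)cc1)N1CCc2ncnc(Nc3cccc(Br)c3)c2C1` gives 51000 nM, two values within the scatter of each other. Compound 4 `O=C(N/N=C/c1cccnc1)N1CCc2ncnc(Nc3cccc(Br)c3)c2C1` differs from compound 3 thus: pyridin-3-yl in place of 4-bromophenyl on a carbon with a double bond to nitrogen, with pyridin-3-yl in place of 4-bromophenyl on a carbon with a double bond to nitrogen. The closest measured change is the loss of bromo, an at least 6.9-fold lower number from compound 1 to compound 2 (0.84 log units; beyond the scatter). The other measured change, an at least 3.9-fold lower number from compound 1 to compound 3 (0.59 log units; beyond the scatter), introduces the 3-bromophenyl that compound 4 retains. Among the measured compounds shown here, both start from a limit, and no measured step covers the ring nitrogen. A modest move to a lower number is therefore expected in this assay, an estimated 3.4-fold lower number from compound 3 to compound 4 (0.53 log units; beyond the scatter). The estimate for compound 4 is 15000 nM, with an expected range of 4000 nM to 60000 nM.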

Compound 4, half-maximal inhibitory concentration: > 200000 nM
Compound 4: no number, only a limit; the forecaster's own chance of this, stated with the estimate: 10%; middle value at least 13-fold (1.12 log units) away from the limit.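

In this assay, pyridin-3-yl in place of 4-bromophenyl gives an at least 3.9-fold higher number from compound 3 to compound 4 (0.59 log units; beyond the scatter), so a change at this position can also raise the number. The other step here, an at least 6.9-fold lower number from compound 1 to compound 2 (0.84 log units; beyond the scatter), runs the opposite way, with 3-chloro-4-fluorophenyl rather than 3-bromophenyl on the nitrogen. The value for compound 4 is a limit, not a number: the limit of > 200000 nM in this assay, at which 2 of the 4 values shown sit.

The compounds shown leave open whether the loss of bromo or the ring nitrogen carries this step. Also open, from the compounds shown here alone, is whether an amine or a methoxy group on this aromatic ring would give a number rather than a limit.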